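Piperazine nitrogen substituent and inhibition in the cytotoxicity series

The source may hold more compounds than are shown below. What is called first, only, known or untested is meant among the compounds shown, and "the series" means these compounds.

Three amides sharing one core have been run in an ADME assay on RAW264.7 cells (Mus musculus) for cytotoxicity, read by MTT assay, with a stated time of 72 h, tested at 50 ug/mL (on this read-out lower numbers stand for less inhibition and higher numbers for more inhibition at the one concentration tested (going by the name of the read-out)), so far. Compound 1 `O=C(c1nc2ccccc2s1)N1CCN(c2ccncc2)CC1` gives 62%; compound 2 `CN1CCN(C(=O)c2nc3ccccc3s2)CC1` gives 52.1%; compound 3 `O=C(c1nc2ccccc2s1)N1CCN(c2ccccc2)CC1` gives 67.2%. Compound 3 holds the highest of the three numbers, with compound 1 nearest (a number 5.2 percentage points higher from compound 1 to compound 3 (within the scatter)) and compound 2 furthest (a number 15.1 percentage points higher from compound 2 to compound 3 (beyond the scatter)). The pair of compound 1 and compound 2 shows a number 9.9 percentage points lower from compound 1 to compound 2 (within the scatter).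

Compound 4 `O=C(c1nc2ccccc2s1)N1CCN(c2cnccn2)CC1` is the next member, differing from compound 3 in one place: pyrazin-2-yl in place of phenyl on an amine nitrogen in a ring. The step that bears most directly on this change is the aryl-for-aryl exchange from compound 1 to compound 3, where pyridin-4-yl gave way to phenyl and the result stayed inside the usual scatter. The larger step from compound 2 to compound 3 concerns methyl, not a second aromatic ring, and is less relevant here. A six-membered aromatic ring with two hetero atoms replacing phenyl is therefore expected to move the read-out little, if anything slightly downward, as in a number 7.2 percentage points lower from compound 3 to compound 4 (within the scatter). On that basis compound 4 is estimated at 60%, with a range from 46% to 72% in this assay .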

Compound 4, a percentage reported as inhibition, at one concentration (the size of the read-out at that concentration, not a potency): 65.3%
For compound 4 the middle estimate is 5.3 percentage points below the measured one; the range from low to high includes it.
By their numbers in this assay, from the lowest: compounds 2, 1, 4 and 3 (each within the scatter of the next, the first and the last beyond it).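

In this assay, pyrazin-2-yl on the amine nitrogen in the ring cannot be separated from either other aromatic ring: the exchange gives a number 1.9 percentage points lower from compound 3 to compound 4 (within the scatter) against phenyl and a number 3.3 percentage points higher from compound 1 to compound 4 (within the scatter) against pyridin-4-yl, although the hydrogen-bond acceptors in the group go from 0 in phenyl to 2 in pyrazin-2-yl. Against methyl there is a number 13.2 percentage points higher from compound 2 to compound 4 (beyond the scatter), so a second aromatic group joins phenyl in standing apart from methyl, while compound 1 goes against this pattern with a number 9.9 percentage points lower from compound 1 to compound 2 (within the scatter). No measurement at hand accounts for these numbers.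

Open, from the compounds shown here alone, is whether a benzyl group, a longer alkyl chain or a cyclohexyl ring on this nitrogen would sit with methyl or with the aromatic groups. Also open, going by these compounds, is whether an amine or a carboxylic acid on the aromatic ring would shift the read-out beyond the scatter.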